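A few compounds are considered here, and "the series" means these few. Any claim that something is new, unique, unknown or untested is made for them only; others in the source may bear on it.

Compound 1 `CC(C)=CCNC(=N)NCCCCCCCCNCCCCCCCCNC(=N)N` is measured in an assay on isolated protein for inhibition of polyamine oxidase 1 (Zea mays), read by spectrophotometry, using a Dixon plot, at pH 6.5 (a lower number here means a stronger inhibitor, a higher number a weaker inhibitor), where compound 1 gives 3 nM, the higher of the two numbers at hand. Compound 2 `C/C=C/CNC(=N)NCCCCCCCCNCCCCCCCCNC(=N)N` shares the same core, and in this assay compound 2 gives 1.1 nM; the step of a 2.7-fold lower number from compound 1 to compound 2 (0.44 log units; beyond the scatter) swaps one alkenyl group for another. Compound 3 `CC(C)=CCNC(=N)NCCCCCCCCNCCCCCCCCNC(=N)NCC=C(C)C` differs from compound 1 by 3-methylbut-2-en-1-yl in place of hydrogen on an amine nitrogen. Within the data shown here, no measured step adds a group at this position, and the single step from compound 1 to compound 2 touches the other end of the chain, so it only loosely guides the expectation. The estimate for compound 3 is 4 nM, spanning 1 nM to 15 nM, an expected step of a 1.3-fold higher number from compound 1 to compound 3 (0.12 log units; within the scatter).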

Compound 3, inhibition constant: 1.7 nM
Beside the measured number, compound 3's estimate is 2.4-fold (0.37 log units) above it; low and high end bracket the measured number.
By their numbers in this assay, from the lowest: compounds 2, 3 and 1 (each within the scatter of the next, the first and the last beyond it).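

Compound 3 shows that this amine nitrogen, whose other neighbour is the carbon with a double bond to nitrogen, can carry a substituent. Putting 3-methylbut-2-en-1-yl in place of hydrogen there gives a 1.8-fold lower number from compound 1 to compound 3 (0.25 log units; within the scatter) in this assay, so the added five carbons leave the number within the scatter and this hydrogen is not needed to keep it this low. Nothing at hand explains this tolerance. From the compounds shown here alone, whether a methyl or a benzyl group on this nitrogen would be tolerated as well stays open.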